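This account rests on a few compounds, and the source may have more. Where it says the series, first, only, none or still open, it means among the compounds named here.

Measured so far:
Compound 1, `C=C1C(=O)O[C@H]2CCCCC[C@@H]12`, gives 102% in a functional assay on P388 cells (Mus musculus) for inhibition, with a stated time of 48 h, tested at 10 ug/mL; on this read-out lower numbers stand for a weaker effect and higher numbers for a stronger effect at the one concentration tested.
Compound 2, `C=C1C(=O)O[C@H]2[C@@H](OC(C)=O)CCCC[C@@H]12`, gives 102% in this assay.

Compound 1 stands level with compound 2 at the digits shown; the one measured step, no change at the digits printed from compound 1 to compound 2 (within the scatter), lies within the scatter, so the two cannot be ranked against each other. The next compound, compound 3, is `C=C1C(=O)O[C@H]2CC[C@@H](C)CC[C@@H]12`. It differs from compound 1 in one place: methyl in place of hydrogen on a saturated ring carbon. Going by the values given here, the only step that bears on this is the one from compound 1 to compound 2, where a group was likewise put onto a saturated ring carbon of the shared core and the read-out of this assay did not move beyond the scatter. On that basis the step from compound 1 to compound 3 is expected to be a number 2 percentage points lower from compound 1 to compound 3 (within the scatter), that is, no change beyond the scatter. Compound 3 is therefore estimated at 100% in this assay, with a likely range from 85% to 110%.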

Compound 3, a percentage reported as activity, at one concentration (the size of the read-out at that concentration, not a potency): 101%
Compound 3: middle estimate off by 1 percentage points, on the low side; the range from low to high includes it.
By their numbers in this assay, from the lowest: compounds 3, 1 and 2 (each within the scatter of the next).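

In this assay, the methyl group on this saturated ring carbon of the seven-membered ring, three ring bonds from two ring atoms that each bear a fused ring, gives a number 1 percentage points lower from compound 1 to compound 3 (within the scatter), so this is a second place on the shared core where a change leaves the read-out within the scatter. The earlier step, no change at the digits printed from compound 1 to compound 2 (within the scatter), concerned an acetoxy group at a different ring carbon, so the result now covers a small carbon-only group at a new position. Nothing available explains why the read-out stays level in either step.

Going by these compounds, whether an amine, a carboxylic acid or a longer chain at this ring carbon would move the read-out remains open. On these data alone, it is also open whether any change to this ring can separate compounds in this assay at the one concentration tested.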